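The compounds below may be only part of what the source reports. "The series", "measured", "known", "first", "only" and "open" are said of these compounds alone.

Measured so far in a functional assay on K562 cells (Homo sapiens) for antiproliferative activity, read by MTT assay, with a stated time of 48 h; on this read-out lower numbers stand for stronger inhibition and higher numbers for weaker inhibition:

compound 1 `CCCCc1ccc2c(c1)C(=O)C(=O)N2` — compound 1 gives > 10000 nM, a limit of this assay rather than a number
compound 2 `C=CCN1C(=O)C(=O)c2cc(-c3ccc(OC)cc3)ccc21` — compound 2 gives 390 nM
compound 3 `COc1ccc(-c2ccc3c(c2)C(=O)C(=O)N3Cc2ccc(F)cc2)cc1` — compound 3 gives 560 nM

Compound 2 holds the lower of the two numbers shown in this assay; its nearest neighbour is compound 3, the step being a 1.4-fold higher number from compound 2 to compound 3 (0.16 log units; within the scatter), so the two are not separated. Compound 1 sits at the limit of > 10000 nM in this assay, at which 1 of the 3 values shown sits, and gives no number to compare.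

Compound 4 `COc1ccc(-c2ccc3c(c2)C(=O)C(=O)N3Cc2ccc(C)cc2)cc1` differs from compound 2 in one place: 4-methylphenyl in place of vinyl on a saturated chain carbon bound to an amide-type nitrogen in a ring. Among the measured compounds shown here, the only measured step at the same place is the one from compound 2 to compound 3, a 1.4-fold higher number from compound 2 to compound 3 (0.16 log units; within the scatter), where a 4-fluorophenyl entered for vinyl and left the number within the scatter. A 4-methylphenyl entering at the same carbon is the closest analogue of that step in the set, so no shift beyond the scatter is expected, the estimated step being a 1.3-fold higher number from compound 2 to compound 4 (0.11 log units; within the scatter). Compound 4 is therefore estimated at 500 nM in this assay, within 200 nM to 1300 nM.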

Compound 4, half-maximal inhibitory concentration: 270 nM
Beside the measured number, compound 4's estimate is 1.9-fold (0.27 log units) above it; low and high end bracket the measured number.
By their numbers in this assay, from the lowest: compounds 4, 2 and 3 (each within the scatter of the next, the first and the last beyond it). At a limit, above all of these: compound 1.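

In this assay, a 1.4-fold lower number from compound 2 to compound 4 (0.16 log units; within the scatter) leaves compound 2 and compound 4 unseparated, so on the saturated chain carbon bound to the ring nitrogen, the 4-methylphenyl is tolerated in place of vinyl. Among the compounds shown here, the change on the aromatic carbon is the first readable one at this end of the molecule: a 2.1-fold lower number from compound 3 to compound 4 (0.32 log units; beyond the scatter) shows that methyl in place of fluoro gives a modest step beyond the scatter, even though compound 2 lies within the scatter of each. Nothing measured here accounts for that step.

Going by these compounds, whether the step extends to other groups on that aromatic carbon, such as a chloro, a methoxy or a carboxylic acid, remains open. So does the outcome of a longer chain or an amine in place of the vinyl.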